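Swapping a fluorine for an ether oxygen on the cyclobutyl side chain

This account rests on a few compounds, and the source may have more. Where it says the series, first, only, none or still open, it means among the compounds named here.

Measured compounds:
compound 1 `CCCCC(C)(C)[C@H](O)/C=C/[C@H]1CCC(=O)N1CCSc1nc(C(=O)O)cs1`: 8.4 nM
compound 2 `O=C(O)c1csc(SCCN2C(=O)OC[C@@H]2/C=C/[C@@H](O)C2(CCCCF)CCC2)n1`: 10 nM
compound 3 `CCCC[C@H](C)C[C@H](O)/C=C/[C@H]1CCC(=O)N1CCSc1nc(C(=O)O)cs1`: 310 nM

In an assay on isolated protein for agonist activity at prostaglandin E2 receptor EP3 subtype (Homo sapiens) (on this read-out higher numbers stand for an effect only at larger amounts of compound and lower numbers for an effect already at smaller amounts), compound 2 gives 10 nM, the second highest of the three numbers; its value and that of compound 1 lie within the scatter of each other, while compound 3 sits far higher. For the measured compounds named here, the only measured step, a 37-fold higher number from compound 1 to compound 3 (1.57 log units; beyond the scatter), concerns a branched chain on the carbon bearing the hydroxyl group, a different place from the one changed here.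

Compound 4 `CCOCCC1([C@H](O)/C=C/[C@H]2COC(=O)N2CCSc2nc(C(=O)O)cs2)CCC1` differs from compound 2 by ethoxy in place of 2-fluoroethyl on a saturated chain carbon, two bonds along the chain from a saturated ring carbon. Going by the values given here, no measured pair probes an exchange of fluorine for an ether oxygen at this place, so the step from compound 1 to compound 3 gives no direct guidance. With nothing shown to the contrary, compound 4 is expected to stay close to compound 2, a change estimated as a 1.2-fold higher number from compound 2 to compound 4 (0.08 log units; within the scatter), not beyond the scatter. Compound 4 is therefore estimated at 12 nM, within a range from 4 nM to 40 nM.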

Compound 4, half-maximal effective concentration: 2610 nM
Beside the measured number, compound 4's estimate is 220-fold (2.34 log units) below it; the whole stated range lies below it.
By their numbers in this assay, from the lowest: compounds 1 and 2 (each within the scatter of the next); then compound 3; then compound 4.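

In this assay this place on the side chain proves highly sensitive to the exchange, which gives a 260-fold higher number from compound 2 to compound 4 (2.42 log units; beyond the scatter). Ethoxy and 2-fluoroethyl have the same count of heavy atoms, and ethoxy differs by carrying oxygen instead of fluorine and one hydrogen-bond acceptor instead of none, so a matching heavy-atom count does not keep the number near that of compound 2 . No measurement at hand explains this large step.

The compounds shown leave open whether the rise follows from having an ether oxygen in this chain at all or from this particular ethoxy group. On these data alone, it also remains open whether a plain propyl group or an amine in place of 2-fluoroethyl would stay close to compound 2 or climb towards compound 4 .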